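The source may report more compounds than this note shows. Statements on the series, on what has been measured and on what is new or still open speak of the compounds shown alone.

Compound 1 `O=C1NC(=O)C2(CSC3=C2C(=O)c2ncccc2C3=O)N1` in a functional assay on SF-268 cells (Homo sapiens) for antiproliferative activity, read by MTT assay, with a stated time of 96 h; on this read-out lower numbers stand for stronger inhibition and higher numbers for weaker inhibition: 3100 nM
Compound 2 `O=C1NN(c2ccc([N+](=O)[O-])cc2)C(=O)C2(CSC3=C2C(=O)c2ncccc2C3=O)N1` in this assay: 3550 nM
Compound 3 `Cc1ccc(N2NC(=O)NC3(CSC4=C3C(=O)c3ncccc3C4=O)C2=O)cc1` in this assay: 2100 nM

All three share one core and differ only in what hangs on one ring nitrogen of that core. Compound 3 gives the smallest of the three numbers, but its distance from compound 1 and from compound 2 is within the usual scatter, so the three cannot be told apart by these values.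

Compound 4 `O=C1NN(c2ccccc2)C(=O)C2(CSC3=C2C(=O)c2ncccc2C3=O)N1` is the next step: hydrogen in place of methyl on an aromatic carbon. The methyl leaves and a hydrogen takes its place on an aromatic carbon of the six-membered carbon ring, so 4-methylphenyl becomes phenyl.

Going by the values given here, one measured step bears on this, the exchange of nitro for methyl on that same ring: a 1.7-fold lower number from compound 2 to compound 3 (0.23 log units; within the scatter). Since swapping two rather different groups there left the number within the scatter, removing the methyl is expected to change little. Compound 4 is therefore expected to give 2500 nM, between 1200 nM and 5500 nM, which means an expected 1.2-fold higher number from compound 3 to compound 4 (0.08 log units; within the scatter).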

Compound 4, half-maximal inhibitory concentration: 2200 nM
Compound 4: the middle estimate sits 1.1-fold (0.06 log units) above what was measured; low and high end bracket the measured number.
By their numbers in this assay, from the lowest: compounds 3, 4, 1 and 2 (each within the scatter of the next).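

Going by these compounds alone, with the plain phenyl compound, this position can for the first time be read against a ring that carries no group at all. In this assay, taking off the methyl gives a 1.0-fold higher number from compound 3 to compound 4 (0.02 log units; within the scatter) and taking off the nitro gives a 1.6-fold lower number from compound 2 to compound 4 (0.21 log units; within the scatter), so neither group, on this aromatic carbon para to a large group, can be told apart from hydrogen by these values. Nothing measured here speaks to why the number stays so flat.

Hydrogen, methyl and nitro are the only groups shown at this position, so it remains open whether an amine, a carboxylic acid or a longer chain would move the number beyond the scatter. Also open, on these data alone, is whether any of these groups would behave the same way on another carbon of that ring.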